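Triazole in Place of Methylthiadiazole on the Thioether Sulfur

A few compounds are considered here, and "the series" means these few. Any claim that something is new, unique, unknown or untested is made for them only; others in the source may bear on it.

Measured so far:
compound 1, `O=C(Nc1ccc(O)c(Sc2nncs2)c1)c1ccc([N+](=O)[O-])cc1` — in an assay on isolated protein for inhibition of RAC-alpha serine/threonine-protein kinase (Homo sapiens), read by fluorescence, with a stated time of 30 min, tested at 10 uM (a lower number here means less inhibition, a higher number more inhibition at the concentration tested (going by the name of the read-out)), compound 1 gives "not active" (no number reported)
compound 2, `Cc1nnc(Sc2cc(NC(=O)c3ccc([N+](=O)[O-])cc3)ccc2O)s1` — in this assay compound 2 gives 12.4%

Compound 2 holds the only number shown in this assay; compound 1 stands beside it with an entry that carries no number at all. Among the measured compounds shown here, no step between measured compounds is available, so compound 2 is the sole anchor. Compound 3, `O=C(Nc1ccc(O)c(Sc2ncn[nH]2)c1)c1ccc([N+](=O)[O-])cc1`, is not yet measured. It differs from compound 2 in one place: 1H-1,2,4-triazol-5-yl in place of 5-methyl-1,3,4-thiadiazol-2-yl on a sulfur. For the measured compounds named here, with a single anchor and no measured step, the account expects no shift beyond the scatter, as the step of a number 2.4 percentage points lower from compound 2 to compound 3 (within the scatter) is estimated to stay small in either direction. Compound 3 is therefore expected to give about 10%, within a range from 0% to 25%, with a real chance that only a statement of inactivity and no number is returned.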

Compound 3, a percentage reported as inhibition, at one concentration (the size of the read-out at that concentration, not a potency): 50.7%
Compound 3: the middle estimate sits 40.7 percentage points below what was measured, outside the stated range (above it).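

In this assay, among the compounds shown here, the group on the sulfur proves to be a sensitive point: 1H-1,2,4-triazol-5-yl in place of 5-methyl-1,3,4-thiadiazol-2-yl gives a number 38.3 percentage points higher from compound 2 to compound 3 (beyond the scatter) and provides the first readable step in this small set. The missing methyl alone does not appear to account for the rise, since compound 1, whose group on the sulfur also carries no methyl, gives "not active" (no number reported) in this assay. Nothing measured here explains why the triazole gives the higher number.

The compounds shown leave open whether a 1H-tetrazol-5-yl or a 1H-imidazol-2-yl on the same sulfur would keep this level of inhibition, and whether a methyl on the triazole would lower it. They also leave open whether the gain would persist with an amine in place of the nitro group, and, with readings at one concentration only, how potent compound 3 is.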